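Capping the hydroxy of compound 2 as methoxy

The compounds below may be only part of what the source reports. "The series", "measured", "known", "first", "only" and "open" are said of these compounds alone.

Compound 1 `Clc1ccc(C[C@H]2COC[C@@H]2Cc2ccccc2)cc1Cl` gives 19000 nM
Compound 2 `Oc1ccc(C[C@H]2COC[C@@H]2Cc2ccc(Cl)c(Cl)c2)cc1` gives 31000 nM

Both compounds were tested in a functional assay on HL-60 cells (Homo sapiens) for cytotoxicity, read by WST assay, with a stated time of 48 h; on this read-out higher numbers stand for an effect only at larger amounts of compound and lower numbers for an effect already at smaller amounts. For the measured compounds named here, compound 2 stands at 31000 nM, the higher of only two numbers, but it lies within the scatter of compound 1 at 19000 nM, so the two cannot be ranked.

Compound 3 `COc1ccc(C[C@H]2COC[C@@H]2Cc2ccc(Cl)c(Cl)c2)cc1` is not yet measured. It differs from compound 2 by methyl in place of hydrogen on an oxygen on an aromatic ring, which is methyl in place of hydrogen on an oxygen on an aromatic ring, or hydroxy to methoxy.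

Going by the values given here, one measured step bears on this change: a 1.6-fold higher number from compound 1 to compound 2 (0.21 log units; within the scatter), with hydroxy in place of hydrogen on an aromatic carbon. That step stayed within the scatter, so replacing hydrogen with hydroxy on this ring made no clear difference in this assay. It says nothing direct about methyl on the oxygen, and a single step shows no trend.

The expected 1.2-fold lower number from compound 2 to compound 3 (0.09 log units; within the scatter) is therefore no larger than the scatter, with no direction favoured. For compound 3 the estimate is 25000 nM, with an expected range from 10000 nM to 60000 nM as its bounds.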

Compound 3, half-maximal effective concentration: 39000 nM
Beside the measured number, compound 3's estimate is 1.6-fold (0.19 log units) below it, and the stated range covers the measured number.
By their numbers in this assay, from the lowest: compounds 1, 2 and 3 (each within the scatter of the next, the first and the last beyond it).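

In this assay, for the compounds shown here, this is the first change made on the oxygen itself, and a 1.3-fold higher number from compound 2 to compound 3 (0.10 log units; within the scatter) stays within the scatter, so methyl in place of hydrogen on this oxygen cannot be told apart from the hydroxy of compound 2. Going by these compounds alone, measured against compound 1, which carries only hydrogen on that ring carbon, a 2.1-fold higher number from compound 1 to compound 3 (0.31 log units; beyond the scatter) is the first step at this place to pass beyond the scatter, although only modestly, so a methoxy there gives a small but readable difference where the hydroxy of compound 2 gave none. Nothing available here bears on the reason for either step.

The compounds shown carry only hydrogen, hydroxy or methoxy at this place, so it stays open whether a longer chain on the oxygen, such as ethoxy, or an amine or a carboxylic acid on the same ring carbon would take the number further from that of compound 1. From the compounds shown here alone, all three values also come from one cell assay, so it remains open whether the modest gap between compound 1 and compound 3 would hold in any other setting.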